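Trimming a Side Chain on a Weakly Active Analogue

This account rests on a few compounds, and the source may have more. Where it says the series, first, only, none or still open, it means among the compounds named here.

Compound 1 `CN(C)CCCNc1nc(NCc2ccc(NC(=O)c3ccc(F)cc3)cc2)c2ccccc2n1`: 10000 nM
Compound 2 `CNc1nc(NCc2ccc(NC(=O)c3ccc(F)cc3)cc2)c2ccccc2n1`: 1600 nM
Compound 3 `CN(C)CCCNc1nc(NCc2ccc(NC(=O)c3ccc(CN4CCN(C)CC4)cc3)cc2)c2ccccc2n1`: > 20000 nM (a limit of the assay, not a number)

In a functional assay on HCT-116 cells (Homo sapiens) for inhibition, read by luminescence and resazurin assay, with a stated time of 3 days (on this read-out higher numbers stand for weaker inhibition and lower numbers for stronger inhibition), compound 3 stands only at the assay's ceiling, (the limit of > 20000 nM in this assay, at which 1 of the 3 values shown sits), so its true number is not known. Compound 4 `CNc1nc(NCc2ccc(NC(=O)c3ccc(CN4CCN(C)CC4)cc3)cc2)c2ccccc2n1` differs from compound 3 by hydrogen in place of 2-(dimethylamino)ethyl on a saturated chain carbon bound to a nitrogen on an aromatic ring. The same change has been measured once in this assay: a 6.3-fold lower number from compound 1 to compound 2 (0.80 log units; beyond the scatter). The other measured step, an at least 2.0-fold higher number from compound 1 to compound 3 (0.30 log units; that floor lies within the scatter), concerns a different position and does not bear directly on this change. If that earlier step carries over, a similar move to a lower number is expected for compound 4, an at least 2.5-fold lower number from compound 3 to compound 4 (0.39 log units; beyond the scatter), though the unknown starting point of compound 3 widens the uncertainty. Compound 4 is therefore estimated at 8000 nM, with a range from 2500 nM to 25000 nM.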

Compound 4, half-maximal inhibitory concentration: 10000 nM
Compound 4: the middle estimate sits 1.3-fold (0.10 log units) below what was measured; the measured number falls inside the stated range.
By their numbers in this assay, from the lowest: compound 2; then compounds 1 and 4 (each within the scatter of the next). At a limit, above all of these: compound 3.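

On the core carrying (4-methylpiperazin-1-yl)methyl, the change to methylamino also moves the number down in this assay, giving an at least 2.0-fold lower number from compound 3 to compound 4 (0.30 log units; that floor lies within the scatter). Compound 3 has only a limit of the assay, > 20000 nM. With methylamino held constant, (4-methylpiperazin-1-yl)methyl in place of fluoro gives a step that can be read in full and lies beyond the scatter, a 6.3-fold higher number from compound 2 to compound 4 (0.80 log units; beyond the scatter).

Going by these compounds, whether each change has the same size on both cores stays open: the same change on two cores in this assay, a 6.3-fold lower number (0.80 log units; beyond the scatter) from compound 1 to compound 2 and an at least 2.0-fold lower number (0.30 log units; that floor lies within the scatter) from compound 3 to compound 4; the limit leaves it open whether they differ How a plain amino group in place of methylamino, or a morpholin-4-ylmethyl group in place of fluoro, would read in this assay also remains open.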